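Compound 4: A Methyl Added to Compound 1

The source may report more compounds than this note shows. Statements on the series, on what has been measured and on what is new or still open speak of the compounds shown alone.

Compound 1 `Cc1ccsc1CN[C@@H]1C[C@H]2C[C@@H]([C@H]1C)C2(C)C` gives 10000 nM in an ADME assay on MDCK cells (Canis lupus familiaris) for cytotoxicity, read by microscopy, with a stated time of 48 h (a higher number here means that more compound is tolerated, a lower number that less compound is tolerated), the second highest of the three numbers. Compound 2 `Cc1ccc(CN[C@@H]2C[C@H]3C[C@@H]([C@H]2C)C3(C)C)s1` gives 780 nM in this assay, and compound 3 `C[C@H]1[C@H](NCc2ccc(Br)s2)C[C@H]2C[C@@H]1C2(C)C` gives 43000 nM. From compound 1 the steps are a 13-fold lower number from compound 1 to compound 2 (1.11 log units; beyond the scatter) and a 4.3-fold higher number from compound 1 to compound 3 (0.63 log units; beyond the scatter); the remaining step is a 55-fold higher number from compound 2 to compound 3 (1.74 log units; beyond the scatter). Compound 4 `CCc1ccsc1CN[C@@H]1C[C@H]2C[C@@H]([C@H]1C)C2(C)C` differs from compound 1 by methyl in place of hydrogen on a saturated chain carbon bound to an aromatic carbon. Among the measured compounds shown here, no measured step goes from methyl to ethyl; the measured steps all alter the group on the saturated chain carbon bound to an amine nitrogen and show that changes there can move the number a great deal. A single added carbon is a smaller change than any measured, so for compound 4 the expected step is no change at the digits printed from compound 1 to compound 4 (within the scatter), within the scatter, with an estimate of 10000 nM and a range from 3000 nM to 30000 nM.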

Compound 4, minimum cytotoxic concentration: 25000 nM
The estimate for compound 4 lay 2.5-fold (0.40 log units) below the measured number; measured number inside the range.
By their numbers in this assay, from the lowest: compound 2; then compound 1; then compounds 4 and 3 (each within the scatter of the next).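

In this assay, methyl in place of hydrogen on a saturated chain carbon bound to an aromatic carbon gives a 2.5-fold higher number from compound 1 to compound 4 (0.40 log units; beyond the scatter), a modest move toward more compound being tolerated. The earlier steps shown here changed the thiophene substituents, whereas this one shows that lengthening the methyl of compound 1 to ethyl also moves the number beyond the scatter. Nothing measured here explains the shift.

On these data alone, whether a longer chain such as propyl would extend this move remains open. So does the outcome of placing an amine or a carboxylic acid on this carbon.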